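Phenyl Gives Way to 1-Benzofuran-2-yl

The source may hold more compounds than are shown below. What is called first, only, known or untested is meant among the compounds shown, and "the series" means these compounds.

Compound 2 `Nc1nc2c(c(-c3ccccc3)cn2[C@@H]2O[C@H](CO)[C@@H](O)[C@H]2O)c(=O)[nH]1` has no exact reading in a functional assay on CCRF-CEM cells (Homo sapiens), read by MTT assay, with a stated time of 72 h; a lower number here means a stronger inhibitor, a higher number a weaker inhibitor. Compound 2 gives > 100000 nM, and this value is a limit. Its closest measured relative is compound 1 `Nc1nc2c(c(-c3cccs3)cn2[C@@H]2O[C@H](CO)[C@@H](O)[C@H]2O)c(=O)[nH]1`, which carries thiophen-2-yl on the shared core. Compound 1 gives > 20000 nM, which is also a limit.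

Compound 3 `Nc1nc2c(c(-c3cc4ccccc4o3)cn2[C@@H]2O[C@H](CO)[C@@H](O)[C@H]2O)c(=O)[nH]1` keeps that core and changes only the aromatic group: 1-benzofuran-2-yl in place of phenyl on an aromatic carbon. Among the compounds with values here, the single measured step that bears on this change is a step that the two limits leave unreadable from compound 1 to compound 2. It swaps one aromatic group for another, yet it offers no size to carry forward.

The expectation therefore rests on weak evidence. Neither measured compound reached a exact reading in this assay, so a large gain in strength seems unlikely for compound 3. At most, a modest shift toward stronger inhibition is expected, and compound 3 may well yield only a limit too. The estimated change is an at least 2.5-fold lower number from compound 2 to compound 3 (0.39 log units; beyond the scatter). For compound 3, the estimated value is 40000 nM, with an expected range from 10000 nM to 100000 nM.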

Compound 3, half-maximal inhibitory concentration: > 20000 nM
Compound 3: only a limit was reported; the forecaster's own chance of this, stated with the estimate: 75%; the middle value is on the limit's open side.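

Compound 1, compound 2 and compound 3 all give only a limit in this assay, so the steps linking compound 3 to compound 1 and to compound 2 cannot be read. The compounds shown leave open how strong each inhibitor is, and whether any of these aromatic groups gives a stronger inhibitor than another.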